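Replacing the Carbamoyl Group with an Aryl Amine

The source may hold more compounds than are shown below. What is called first, only, known or untested is meant among the compounds shown, and "the series" means these compounds.

Measured compounds:
compound 1 `CCCCCCCC(=O)Nc1nc2ccc(NC(=O)c3c(Cl)cccc3Cl)cc2s1` gives 0.18 ug/mL in a functional assay on WI-38 VA13 cells (Homo sapiens) for cytotoxicity; a lower number here means that less compound is needed, a higher number that more compound is needed for the effect;
compound 2 `CCCOC(=O)Nc1nc2ccc(NC(=O)c3c(Cl)cccc3Cl)cc2s1` gives 0.0025 ug/mL;
compound 3 `O=C(NCc1ccccc1)Nc1nc2ccc(NC(=O)c3c(Cl)cccc3Cl)cc2s1` gives 0.15 ug/mL.

Compound 3 stands second highest of the three numbers in this assay. Its nearest neighbour is compound 1 a 1.2-fold lower number from compound 1 to compound 3 (0.08 log units; within the scatter), its furthest compound 2 a 60-fold higher number from compound 2 to compound 3 (1.78 log units; beyond the scatter). Compound 4 `COc1ccccc1Nc1nc2ccc(NC(=O)c3c(Cl)cccc3Cl)cc2s1` differs from compound 3 by 2-methoxyphenyl in place of benzylcarbamoyl on a nitrogen on an aromatic ring. For the measured compounds named here, none of the measured steps removes the carbonyl itself; they only change what sits on its carbon, and there two of them were large a 72-fold lower number from compound 1 to compound 2 (1.86 log units; beyond the scatter) a 60-fold higher number from compound 2 to compound 3 (1.78 log units; beyond the scatter) while one stayed within the scatter a 1.2-fold lower number from compound 1 to compound 3 (0.08 log units; within the scatter). The expectation for compound 4 therefore rests on little, and its number is estimated near that of compound 3 with a wide range, a 2.0-fold higher number from compound 3 to compound 4 (0.30 log units; within the scatter), at 0.3 ug/mL between 0.03 ug/mL and 3 ug/mL.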

Compound 4, half-maximal effective concentration: > 7.2 ug/mL
Compound 4: no number, only a limit (the forecaster's own chance of this, stated with the estimate: 10%); middle value at least 24-fold (1.38 log units) away from the limit.
By their numbers in this assay, from the lowest: compound 2; then compounds 3 and 1 (each within the scatter of the next). At a limit, above all of these: compound 4.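

Compound 4 gives only a limit in this assay, not a number: the limit of > 7.2 ug/mL in this assay, at which 1 of the 4 values shown sits. Taking the carbonyl off this nitrogen, which no earlier step had done, and setting 2-methoxyphenyl there gives large rises against all three carbonyl compounds: an at least 48-fold higher number from compound 3 to compound 4 (1.68 log units; beyond the scatter), an at least 40-fold higher number from compound 1 to compound 4 (1.60 log units; beyond the scatter) and an at least 2800-fold higher number from compound 2 to compound 4 (3.45 log units; beyond the scatter). The carbonyl compounds thus span a wide range among themselves, yet all three lie beyond the scatter from compound 4.

The compounds shown leave open whether the loss of the carbonyl or the 2-methoxyphenyl group itself carries this rise. Going by these compounds, how a plain phenyl or a free amine on this nitrogen would read also stays open.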